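The compounds below may be only part of what the source reports. "The series", "measured", "known", "first", "only" and "open" are said of these compounds alone.

In a functional assay on cells (leukaemia cell line, Homo sapiens) for inhibition, read by sulforhodamine B assay, with a stated time of 48 h (on this read-out higher numbers stand for weaker inhibition of growth and lower numbers for stronger inhibition of growth), compound 1 (`O=S(=O)(Nc1ccc(F)c(Cl)c1)c1ccc(-c2cnc(C3CC3)o2)cc1`) gives 260 nM and compound 2 (`COc1cc(NS(=O)(=O)c2ccc(-c3cnc(C4CC4)o3)cc2)ccc1F`) gives 328 nM as its value. Going by the values given here, compound 2 thus stands within the scatter of compound 1, the only other measured member of the series, and the two cannot be separated. The next compound, compound 3 (`O=S(=O)(Nc1ccc(I)c(Cl)c1)c1ccc(-c2cnc(C3CC3)o2)cc1`), carries 3-chloro-4-iodophenyl in place of 4-fluoro-3-methoxyphenyl on a sulfonamide nitrogen. Among the compounds with values here, one measured step bears on this: methoxy in place of chloro (a 1.3-fold higher number from compound 1 to compound 2 (0.10 log units; within the scatter)), which stayed within the scatter. Compound 3 has chloro where compound 2 has methoxy, so that part of the change is the same swap in reverse, and little is expected from it. Within the data shown here, no measured step covers iodine in place of fluorine, and that part remains open, which widens the range. In this assay no step beyond the scatter is expected, in either direction. The expected step is a 1.2-fold lower number from compound 2 to compound 3 (0.08 log units; within the scatter) and it stays within the scatter. The estimate for compound 3 is 270 nM with an expected range from 110 nM to 680 nM in this read-out.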

Compound 3, concentration for 50% growth inhibition: 1010 nM
Beside the measured number, compound 3's estimate is 3.7-fold (0.57 log units) below it; measured number outside the range, above it.
By their numbers in this assay, from the lowest: compounds 1 and 2 (each within the scatter of the next); then compound 3.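

In this assay, going by these compounds alone, this position on the sulfonamide nitrogen is no longer flat: iodo in place of fluoro on an aromatic carbon gives a 3.9-fold higher number from compound 1 to compound 3 (0.59 log units; beyond the scatter) and is the first single change to leave the scatter, while the swap of the whole aryl group gives a 3.1-fold higher number from compound 2 to compound 3 (0.49 log units; beyond the scatter) in the same direction. The earlier pair showed only that methoxy and chloro could not be told apart with fluoro kept, so the shift now seen travels with 3-chloro-4-iodophenyl, and compound 3 stands apart from compound 1 and compound 2 on this read-out. No measurement at hand gives a reason for this shift.

Going by these compounds, whether bromo, a methyl group, an amine or a carboxylic acid in place of iodo would sit with compound 1 or with compound 3 remains open, so a single iodo example cannot yet show a trend across substituents at that carbon. Also open is whether iodo would give a step of the same size with methoxy in place of chloro, since that combination does not appear among the compounds shown.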